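This account rests on a few compounds, and the source may have more. Where it says the series, first, only, none or still open, it means among the compounds named here.

Measured in a functional assay on CEM-CCRF cells for antagonist activity at C-X-C chemokine receptor type 4 (Homo sapiens), read by calcium flux; a lower number here means a stronger inhibitor, a higher number a weaker inhibitor:
compound 1 `NC/C=C\CN(Cc1nc2ccccc2[nH]1)C1CCCc2cccnc21` gives 77 nM
compound 2 `NC/C=C/CN(Cc1nc2ccccc2[nH]1)C1CCCc2cccnc21` gives 160 nM

Compound 1 has the lower of the two numbers; the step of a 2.1-fold higher number from compound 1 to compound 2 (0.32 log units; beyond the scatter) is modest but beyond the scatter, and since these two compounds share every atom and bond and differ only in how the double bond is drawn (the fact that one of compounds 1 and 2 is drawn with a defined configuration and the other without, at the place where they differ), the geometry of the chain alone accounts for that gap.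

Compound 3 `CNCCCCN(Cc1nc2ccccc2[nH]1)C1CCCc2cccnc21` is not yet measured. It differs from compound 1 in this way: 3-(methylamino)propyl in place of 3-aminoprop-1-en-1-yl on a saturated chain carbon bound to an amine nitrogen. Going by the values given here, no measured step matches this change. The double bond is removed rather than redrawn, and a methyl group enters on the amine nitrogen at the same time. The step from compound 1 to compound 2 only shows that the chain's shape shifts the number modestly. The expectation for compound 3 in this assay is therefore a small loss, a 1.7-fold higher number from compound 1 to compound 3 (0.23 log units; within the scatter), with wide uncertainty. Compound 3 is estimated at 130 nM, within the range 40 nM to 450 nM.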

Compound 3, half-maximal inhibitory concentration: 190 nM
Compound 3: the middle estimate sits 1.5-fold (0.16 log units) below what was measured, within the range that was stated.
By their numbers in this assay, from the lowest: compound 1; then compounds 2 and 3 (each within the scatter of the next).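

In this assay, putting 3-(methylamino)propyl in place of 3-aminoprop-1-en-1-yl gives a 2.5-fold higher number from compound 1 to compound 3 (0.39 log units; beyond the scatter) and so costs only a modest amount: a chain with no double bond still gives an inhibitor. Measured against the E-drawn chain instead, the same change gives a 1.2-fold higher number from compound 2 to compound 3 (0.07 log units; within the scatter) and shows no real difference, which leaves the Z-drawn chain as the only one of the three set apart by its number. Nothing measured here explains why the saturated chain behaves this way.

The removal of the double bond and the added methyl on the nitrogen arrive together, and their separate shares cannot be read from these compounds. A saturated chain ending in a plain primary amine would address that, while a longer chain or a dimethylamino end remains an open question.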